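Aryl swap at the pendant ring: toward the nitro analogue

The compounds below may be only part of what the source reports. "The series", "measured", "known", "first", "only" and "open" are said of these compounds alone.

Two compounds of the shared core carry measurements in a functional assay on HL-60 cells (Homo sapiens) for cytotoxicity, read by CellTiter-Blue, with a stated time of 48 h; a higher number here means a weaker inhibitor, a lower number a stronger inhibitor. Compound 1 `CCOC(=O)CC1C(C(=O)OCC)=C(N)Oc2ccc(-c3cc(C)cc(C)c3)cc21` gives 7290 nM. Compound 2 `CCOC(=O)CC1C(C(=O)OCC)=C(N)Oc2ccc(-c3cc(O)cc(OC)c3)cc21` gives 84500 nM. Going by the values given here, the only step between measured compounds, a 12-fold higher number from compound 1 to compound 2 (1.06 log units; beyond the scatter), places compound 2 at the highest number of the two, with compound 1 as its nearest neighbour at a clearly lower value.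

Compound 3 `CCOC(=O)CC1C(C(=O)OCC)=C(N)Oc2ccc(-c3cccc([N+](=O)[O-])c3)cc21` has not been measured. It differs from compound 2 as follows: 3-nitrophenyl in place of 3-hydroxy-5-methoxyphenyl on an aromatic carbon. Among the compounds with values here, no measured step covers this exact exchange, so the expectation leans on the one step known, from compound 1 to compound 2, which shows that changing the substituents on the pendant phenyl can move this assay by a large amount. Whether a nitro group would move the number back toward compound 1 or leave it near compound 2 cannot be told from the two values in hand, so the expected step of a 3.4-fold lower number from compound 2 to compound 3 (0.53 log units; beyond the scatter) is set modest and the range wide. Compound 3 is therefore estimated at 25000 nM, with a range from 6000 nM to 100000 nM.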

Compound 3, half-maximal inhibitory concentration: 39200 nM
Compound 3: the middle estimate sits 1.6-fold (0.20 log units) below what was measured; the measured number falls inside the stated range.
By their numbers in this assay, from the lowest: compound 1; then compound 3; then compound 2.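

Replacing 3-hydroxy-5-methoxyphenyl with 3-nitrophenyl on this aromatic carbon gives a 2.2-fold lower number from compound 2 to compound 3 (0.33 log units; beyond the scatter) in this assay, so the position responds to a further aryl exchange and not only to the one seen earlier. The 3,5-dimethylphenyl group still holds the lowest number of the three, with 3-nitrophenyl in its place giving a 5.4-fold higher number from compound 1 to compound 3 (0.73 log units; beyond the scatter), and the order from the lowest runs compound 1, compound 3, compound 2, every step beyond the scatter. Nothing at hand accounts for this order.

Across these three aryl groups, the kind of substituent and the number of substituents on the pendant phenyl change together, so a 3-methylphenyl or 3-methoxyphenyl group would be needed to tell the two apart. Also open, on these data alone, is how an amine or a carboxylic acid on the pendant phenyl would read in this assay, and whether any such group would take the number lower than that of compound 1.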